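The source may hold more compounds than are shown below. What is called first, only, known or untested is meant among the compounds shown, and "the series" means these compounds.

Compound 2 `COc1cc(-n2ncnc2-c2ccc(OC(F)(F)F)cc2)cc(OC)c1OC` carries trifluoromethyl on an oxygen on an aromatic ring. In a functional assay on HeLa cells (Homo sapiens) for antiproliferative activity, read by MTT assay, with a stated time of 72 h (a lower number here means a stronger inhibitor, a higher number a weaker inhibitor), compound 2 gives > 10000 nM, which is a limit of the assay and not a number (the limit of > 10000 nM in this assay, at which 1 of the 2 values shown sits). Among the measured compounds shown here, compound 1 `COc1ccc(-c2ncnn2-c2cc(OC)c(OC)c(OC)c2)cc1`, with methyl on that oxygen instead, gives 280 nM in this assay, and the one measured step, an at least 35-fold higher number from compound 1 to compound 2 (1.55 log units; beyond the scatter), is the only step that bears on the present change. Compound 3 `COc1cc(-n2ncnc2-c2ccc(OC(C)C)cc2)cc(OC)c1OC` differs from compound 2 as follows: isopropyl in place of trifluoromethyl on an oxygen on an aromatic ring. Isopropyl is a third group, neither of the two already measured, so the shown step fixes only the span between methyl and trifluoromethyl in this assay; where isopropyl falls within or outside that span is not known from these data. Compound 3 is expected to give a number rather than a limit, the step of an at least 3.3-fold lower number from compound 2 to compound 3 (0.52 log units; beyond the scatter) being estimated as a partial recovery. The estimate for compound 3 is 3000 nM, with a range from 500 nM to 10000 nM.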

Compound 3, half-maximal inhibitory concentration: 600 nM
Compound 3: middle estimate off by 5.0-fold (0.70 log units), on the high side; the measured number falls inside the stated range.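

In this assay, the loss seen with trifluoromethyl on this oxygen is not shared by every group other than methyl: the change to isopropyl gives an at least 16-fold lower number from compound 2 to compound 3 (1.22 log units; beyond the scatter) and places compound 3 close to the methyl compound. Measured against methyl, isopropyl gives a 2.1-fold higher number from compound 1 to compound 3 (0.33 log units; beyond the scatter) and so costs far less than trifluoromethyl does, though the step is still beyond the scatter. On these data alone, compound 2 remains a limit of the assay and not a number, so the full size of its loss is unknown: the limit of > 10000 nM in this assay, at which 1 of the 3 values shown sits.

The three groups shown do not separate the effect of fluorine from that of the group as a whole, a question that difluoromethyl or ethyl on the same oxygen would bear on. Where a longer chain such as n-butyl, or an amine in place of the oxygen, would fall remains open.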